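Relocating the chloro group on the phenyl of compound 2

The source may report more compounds than this note shows. Statements on the series, on what has been measured and on what is new or still open speak of the compounds shown alone.

The series shares one core. Compound 1 `O=c1oc2cccnc2n1CN1CCN(c2ccc(F)cc2)CC1`, compound 2 `O=c1oc2cccnc2n1CN1CCN(c2ccc(Cl)cc2)CC1` and compound 3 `O=c1oc2cccnc2n1CN1CCN(c2cccc(C(F)(F)F)c2)CC1` have been measured in a functional assay on the whole organism with Mus musculus as the target; a higher number here means that more compound is needed for the effect, a lower number that less compound is needed. Compound 1 gives 3.5 mg/kg, compound 2 gives 10.6 mg/kg and compound 3 gives 3.6 mg/kg. Compound 2 stands highest of the three numbers; its nearest neighbour is compound 3 and its furthest is compound 1, both gaps beyond the scatter. Among the compounds with values here, the only measured step, a 3.0-fold higher number from compound 1 to compound 2 (0.48 log units; beyond the scatter), exchanges one halogen for another and is modest.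

Compound 4 `O=c1oc2cccnc2n1CN1CCN(c2ccccc2Cl)CC1` is not yet measured. It differs from compound 2 by 2-chlorophenyl in place of 4-chlorophenyl on an amine nitrogen in a ring. Within the data shown here, no measured step moves a group to a new position on this phenyl ring; the step from compound 1 to compound 2 changes only the halogen, so it gives a sense of step size but no direction. Among the measured compounds shown here, compound 3, which carries a trifluoromethyl group, has no recorded step to compound 2, and its value simply sits lower. The expected step of a 1.5-fold lower number from compound 2 to compound 4 (0.18 log units; within the scatter) is therefore small, with wide uncertainty. Compound 4 is expected to give 7 mg/kg, within 2.5 mg/kg to 20 mg/kg.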

Compound 4, dose for half-maximal effect: 22.2 mg/kg
For compound 4 the middle estimate is 3.2-fold (0.50 log units) below the measured one, outside the stated range (above it).
By their numbers in this assay, from the lowest: compounds 1 and 3 (each within the scatter of the next); then compound 2; then compound 4.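

In this assay the position of the chloro group on the phenyl ring matters on its own: with the same atoms joined differently, 2-chlorophenyl in place of 4-chlorophenyl gives a step beyond the scatter (a 2.1-fold higher number from compound 2 to compound 4 (0.32 log units; beyond the scatter)). Within the data shown here, the earlier step changed only the halogen, so this is the first direction seen for a change of position on this ring, and it runs towards more compound being needed. Both changes together, the halogen and its position, give the largest step among the compounds shown (a 6.3-fold higher number from compound 1 to compound 4 (0.80 log units; beyond the scatter)), and nothing here supplies a reason for either shift.

Still open is whether the shift belongs to chloro alone, since no other group, such as fluoro, methoxy or an amine, is shown in the place it takes in 2-chlorophenyl. The trifluoromethyl group of compound 3 likewise has no positional partner, so it cannot show whether that group responds to a move in the same way.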